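From 2-chlorophenyl to 2-methoxyphenyl in a small series

The source may report more compounds than this note shows. Statements on the series, on what has been measured and on what is new or still open speak of the compounds shown alone.

Measured in a functional assay on DU-145 cells (Homo sapiens) for inhibition, read by MTT assay, with a stated time of 72 h; on this read-out higher numbers stand for weaker inhibition and lower numbers for stronger inhibition:
- compound 1 `O=C1C=C(N2CCN(c3ccc(Cl)cc3)CC2)C(=O)c2ccccc21` gives 29500 nM
- compound 2 `Cc1ccc(N2CCN(C3=CC(=O)c4ccccc4C3=O)CC2)cc1` gives 8200 nM
- compound 3 `O=C1C=C(N2CCN(c3ccccc3Cl)CC2)C(=O)c2ccccc21` gives 2900 nM

Among these three, compound 3 has the lowest number, 2900 nM. It stands closest to compound 2, with a 2.8-fold lower number from compound 2 to compound 3 (0.45 log units; beyond the scatter), and furthest from compound 1, with a 10-fold lower number from compound 1 to compound 3 (1.01 log units; beyond the scatter).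

Compound 4 `COc1ccccc1N1CCN(C2=CC(=O)c3ccccc3C2=O)CC1` has not yet been measured. It carries methoxy in place of chloro on an aromatic carbon, ortho to a large group: methoxy in place of chloro on an aromatic carbon.

For the measured compounds named here, no measured step makes this exact change. The nearest is a 3.6-fold lower number from compound 1 to compound 2 (0.56 log units; beyond the scatter), where methyl replaces chloro in the 4-substituted compounds, so it brings in neither methoxy nor the same place on the ring. The step of a 10-fold lower number from compound 1 to compound 3 (1.01 log units; beyond the scatter) shows that the place of a chloro alone can matter in this assay, which limits how far the methyl step can be carried over. A modest step in either direction therefore remains possible, and the likeliest outcome is none beyond the scatter, with a slight lean towards a higher number.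

The expected step is a 1.3-fold higher number from compound 3 to compound 4 (0.12 log units; within the scatter). For compound 4 the estimated value is 3800 nM, with an expected range of 1200 nM to 12000 nM.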

Compound 4, half-maximal inhibitory concentration: 8000 nM
Compound 4: the middle estimate sits 2.1-fold (0.32 log units) below what was measured, within the range that was stated.
By their numbers in this assay, from the lowest: compound 3; then compounds 4 and 2 (each within the scatter of the next); then compound 1.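

For the compounds shown here, on the ortho place, methoxy is not an even exchange for chloro in this assay: this is the first measured change of group at that place, and the step (a 2.8-fold higher number from compound 3 to compound 4 (0.44 log units; beyond the scatter)) goes against compound 3, which held the lowest number so far. The good standing of 2-chlorophenyl therefore does not carry over to every group there, since the 2-methoxyphenyl group cannot be told apart from 4-methylphenyl (a 1.0-fold lower number from compound 2 to compound 4 (0.01 log units; within the scatter)), although it keeps a clear margin over 4-chlorophenyl (a 3.7-fold lower number from compound 1 to compound 4 (0.57 log units; beyond the scatter)). Nothing on hand explains why this exchange moves the number.

The compounds shown leave open how other groups would behave on the ortho place, for instance fluoro, hydroxy or a dimethylamino group, and so whether chloro is unusual there or methoxy is the poorer fit. They also leave open whether methoxy on the 4-substituted phenyl would follow the same course, as chloro is the only group shown in both places, and there its place alone changes the number considerably (a 10-fold lower number from compound 1 to compound 3 (1.01 log units; beyond the scatter)).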